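Chloro in place of methoxy: compound 2 to compound 3

The source may hold more compounds than are shown below. What is called first, only, known or untested is meant among the compounds shown, and "the series" means these compounds.

Measured compounds
- compound 1, `O=C1c2ccc(OCc3cccc(-c4ccccc4)c3)cc2CN1C1CCCC1`: "not determined" (no result reported) in an assay on HEK293 cells for positive allosteric modulation of metabotropic glutamate receptor 2 (Rattus norvegicus), read by thallium flux; on this read-out lower numbers stand for smaller maximal responses and higher numbers for larger maximal responses
- compound 2, `COc1ccc(C(=O)O)cc1-c1cccc(COc2ccc3c(c2)CN(C2CCCC2)C3=O)c1`: 79.2%

In this assay, going by the values given here, compound 2 gives 79.2%, and that is the only number available; compound 1 carries no result, so compound 2 cannot be placed relative to anything else, and no step between measured compounds exists. Compound 3, `O=C(O)c1ccc(Cl)c(-c2cccc(COc3ccc4c(c3)CN(C3CCCC3)C4=O)c2)c1`, has not yet been measured. It differs from compound 2 in one place: chloro in place of methoxy on an aromatic carbon. The change is small in count, one heavy atom entering for two leaving, on the ring that carries the carboxy group, and the rest of the molecule is unchanged.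

Among the compounds with values here, with no measured step anywhere to lean on, there is nothing in the numbers that points up or down. The step expected here, a number 0.8 percentage points higher from compound 2 to compound 3 (within the scatter), is therefore taken as lying within the usual scatter of this assay. Compound 3 is accordingly expected to give about 80%, with a plausible range from 62% to 98%.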

Compound 3, largest response reached (reported as percent of maximum), in percent of the reference or control that the assay uses: 93.9%
Beside the measured number, compound 3's estimate is 13.9 percentage points below it; low and high end bracket the measured number.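

In this assay, going by these compounds alone, chloro in place of methoxy, at the position ortho to a large group and para to a carboxy group, gives a number 14.7 percentage points higher from compound 2 to compound 3 (beyond the scatter) and is the only readable step so far. It shows that the maximal response at this position is sensitive to the group on this aromatic carbon, and that the 5-carboxy-2-chlorophenyl variant keeps the response rather than losing it when methoxy leaves, even though only one heavy atom enters for two. Nothing measured in this set bears on why the two compounds differ.

The compounds shown leave open whether this rise belongs to chloro alone or would also appear with fluoro, methyl, trifluoromethyl or an ethoxy group at the same position, since a single pair fixes no trend. Also open, from the compounds shown here alone, are the role of the carboxy group on this ring, for which a primary amide or a nitrile would be the direct comparison, and whether the step holds with a group other than cyclopentyl on the lactam nitrogen of the shared core.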